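Ring substituent changes in a chemokine receptor antagonist series

The compounds below may be only part of what the source reports. "The series", "measured", "known", "first", "only" and "open" are said of these compounds alone.

Measured compounds in a functional assay on cells for antagonist activity at C-C chemokine receptor type 4 (Homo sapiens), read by fluorescence and calcium flux, with stated times of 2.5 s and 45 s; on this read-out lower numbers stand for stronger inhibition and higher numbers for weaker inhibition:
- compound 1 `Cc1nn([C@H](C)c2ccc(Cl)cc2Cl)c2nc(N3CC[C@H](N4CCCC4)[C@H](C)C3)cnc12`: 69 nM
- compound 2 `Cc1nn([C@H](C)c2ccc(Cl)cc2Cl)c2nc(N3CC[C@H](N4CCC[C@H]4C(N)=O)[C@H](C)C3)cnc12`: 170 nM
- compound 3 `Cc1nn([C@H](C)c2ccc(Cl)cc2Cl)c2nc(N3CC[C@H](N4CCCCC4)[C@H](C)C3)cnc12`: 42 nM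

Compound 3 gives the lowest number of the three in this assay. Against compound 1 its step is a 1.6-fold lower number from compound 1 to compound 3 (0.22 log units; within the scatter), so the two cannot be separated. Against compound 2 the step is a 4.0-fold lower number from compound 2 to compound 3 (0.61 log units; beyond the scatter), which does separate them. Among the measured compounds shown here, the one step that adds a group to the saturated ring is a 2.5-fold higher number from compound 1 to compound 2 (0.39 log units; beyond the scatter).

Compound 4 `Cc1nn([C@H](C)c2ccc(Cl)cc2Cl)c2nc(N3CC[C@H](N4CCC[C@H]4C(=O)O)[C@H](C)C3)cnc12` is not yet measured. Relative to compound 3 the change is 2-carboxypyrrolidin-1-yl in place of piperidin-1-yl on a saturated ring carbon. For the measured compounds named here, the closest measured step is the reverse of the one from compound 2 to compound 3, where the 2-carbamoylpyrrolidin-1-yl group stood in place of piperidin-1-yl; no measured pair shows a carboxy group against a carbamoyl group, so that part of the change is not covered by the data. On the basis of compound 2 and its value 170 nM, compound 4 is expected to give a higher number than compound 3 in this assay, with a step of about a 4.8-fold higher number from compound 3 to compound 4 (0.68 log units; beyond the scatter), beyond the scatter. The estimate for compound 4 is 200 nM, with a range from 70 nM to 600 nM.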

Compound 4, half-maximal inhibitory concentration: 670 nM
The estimate for compound 4 lay 3.4-fold (0.53 log units) below the measured number; measured number above the stated range.
By their numbers in this assay, from the lowest: compounds 3 and 1 (each within the scatter of the next); then compound 2; then compound 4.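

In this assay, the group on the saturated ring carbon three ring bonds from the ring nitrogen proves sensitive to the end of the carbonyl substituent and not only to its presence: with the 2-substituted pyrrolidin-1-yl ring kept, hydroxy in place of amino on the carbonyl carbon gives a 3.9-fold higher number from compound 2 to compound 4 (0.60 log units; beyond the scatter) and separates the carboxy group from the carbamoyl group. Set against the unsubstituted ring, the carboxy group gives a 9.7-fold higher number from compound 1 to compound 4 (0.99 log units; beyond the scatter) and the combined change from piperidin-1-yl gives a 16-fold higher number from compound 3 to compound 4 (1.20 log units; beyond the scatter) so the three pyrrolidin-1-yl compounds now fall in a clear order, with hydrogen lowest, then carbamoyl, then carboxy, and compound 4 gives the highest number of the series. No measurement on these compounds accounts for this order.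

The compounds shown leave open whether the same order holds on the piperidin-1-yl ring, as a 2-carboxypiperidin-1-yl or 2-carbamoylpiperidin-1-yl group would show, and whether the opposite configuration at the carbon bearing the carboxy group changes the number. They also leave open where a methyl ester or a hydroxymethyl group at that ring carbon would fall relative to the carbamoyl and carboxy groups.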